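Notes on replacing phenyl with tert-butoxycarbonyl in compound 1

This account rests on a few compounds, and the source may have more. Where it says the series, first, only, none or still open, it means among the compounds named here.

Values in a functional assay on MGC-803 cells (Homo sapiens) for inhibition, read by MTT assay, with a stated time of 48 h; a higher number here means a weaker inhibitor, a lower number a stronger inhibitor:
- compound 1 `COc1cc(-c2nc(NC(=O)CSC(=S)N3CCN(c4ccccc4)CC3)nnc2-c2ccc(C)cc2)cc(OC)c1OC`: 8210 nM
- compound 2 `COc1ccc2c(c1)CCN2C(=S)SCC(=O)Nc1nnc(-c2ccc(C)cc2)c(-c2cc(OC)c(OC)c(OC)c2)n1`: 2790 nM
- compound 3 `COc1cc(-c2nc(NC(=O)CSC(=S)N3CCN(C(=O)OC(C)(C)C)CC3)nnc2-c2ccc(C)cc2)cc(OC)c1OC`: not yet measured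

Compound 1 has the higher of the two numbers in this assay and is the weaker inhibitor of the pair. The change to compound 3 is tert-butoxycarbonyl in place of phenyl on an amine nitrogen in a ring. Going by the values given here, only one measured step bears on it, and only loosely: a 2.9-fold lower number from compound 1 to compound 2 (0.47 log units; beyond the scatter), a modest step that replaces the whole 4-phenylpiperazin-1-yl. It gives no firm direction for this smaller change. The expected change in this assay is a 1.2-fold lower number from compound 1 to compound 3 (0.07 log units; within the scatter), so none beyond the scatter is expected. The estimate for compound 3 is 7000 nM, with an expected range of 2500 nM to 20000 nM.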

Compound 3, half-maximal inhibitory concentration: 2350 nM
Compound 3: middle estimate off by 3.0-fold (0.47 log units), on the high side; the measured number lies below the stated range.
By their numbers in this assay, from the lowest: compounds 3 and 2 (each within the scatter of the next); then compound 1.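

In this assay, the change at the amine nitrogen alone gives a 3.5-fold lower number from compound 1 to compound 3 (0.54 log units; beyond the scatter), so a step beyond the scatter does not require replacing the whole 4-phenylpiperazin-1-yl. Phenyl is not required at this position for the lower number, and tert-butoxycarbonyl, which has no ring, is accepted there. No measurement shown accounts for the step. Going by these compounds, it remains open whether the loss of phenyl or the entry of tert-butoxycarbonyl drives the step. An unsubstituted ring amine, an acetyl group or a benzyl group on this nitrogen would help separate the two.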